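Compound 1 to compound 3: a larger ether group

The compounds below may be only part of what the source reports. "The series", "measured", "known", "first", "only" and "open" are said of these compounds alone.

For the measured compounds named here, in a functional assay on SK-OV-3 cells (Homo sapiens) for inhibition, read by CCK-8 assay, with a stated time of 70 h (a higher number here means a weaker inhibitor, a lower number a stronger inhibitor), compound 1 `COc1ccc(OCCOCCNC2CCCC2)cc1` gives 99100 nM, the higher of the two numbers so far. Compound 2 `c1ccc(COc2ccc(COc3ccc(OCCOCCNC4CCCCC4)cc3)cc2)cc1` gives 8080 nM, a gap beyond the scatter, though the two differ in more than one place. Compound 3 `Nc1ccc(COc2ccc(OCCOCCNC3CCCC3)cc2)cc1` changes compound 1 as follows: 4-aminophenyl in place of hydrogen on a saturated chain carbon bound to an oxygen on an aromatic ring. Methoxy thus becomes (4-aminobenzyl)oxy. Compound 2 also carries a larger group than methoxy and reads 8080 nM, so a lower number is expected for compound 3, probably not as low. The expected change is a 3.3-fold lower number from compound 1 to compound 3 (0.52 log units; beyond the scatter). For compound 3 the estimated value is 30000 nM, with an expected range of 10000 nM to 80000 nM.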

Compound 3, half-maximal inhibitory concentration: 31700 nM
Beside the measured number, compound 3's estimate is 1.1-fold (0.02 log units) below it, and the stated range covers the measured number.
By their numbers in this assay, from the lowest: compound 2; then compound 3; then compound 1.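

Methoxy to (4-aminobenzyl)oxy on the core of compound 1 gives a 3.1-fold lower number from compound 1 to compound 3 (0.50 log units; beyond the scatter) and is the first step in the series that differs in one place. It shows that 4-aminophenyl on a saturated chain carbon bound to an oxygen on an aromatic ring lowers the number, though the step is modest. No other data bear on this result.

Whether the added ring alone accounts for the step, or the amine on it also contributes, stays open. A plain benzyl group, or a carboxylic acid in place of the amine, would separate the two.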